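Aryl swaps on the shared core: 1,2-thiazol-4-yl variant

The source may report more compounds than this note shows. Statements on the series, on what has been measured and on what is new or still open speak of the compounds shown alone.

Compound 1 `CCC(C)(C)Cc1c[nH]c(CCc2ccc(-n3cccn3)cc2)n1` gives 106 nM in a functional assay on HEK293 cells for agonist activity at Bombesin receptor subtype-3 (Homo sapiens), read by luminescence and calcium flux, with a stated time of 10 min; a higher number here means that more compound is needed for the effect, a lower number that less compound is needed.
Compound 2 `CCC(C)(C)Cc1c[nH]c(CCc2ccc(-n3ccnn3)cc2)n1` gives 93 nM in this assay.
Compound 3 `CCC(C)(C)Cc1c[nH]c(CCc2ccc(-c3cccc(C#N)n3)cc2)n1` gives 95 nM in this assay.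

Compound 3 stands second highest of the three numbers, but every step among them is within the scatter: nearest is a 1.0-fold higher number from compound 2 to compound 3 (0.01 log units; within the scatter), furthest a 1.1-fold lower number from compound 1 to compound 3 (0.05 log units; within the scatter).

Compound 4 `CCC(C)(C)Cc1c[nH]c(CCc2ccc(-c3cnsc3)cc2)n1` differs from compound 3 by 1,2-thiazol-4-yl in place of 6-cyanopyridin-2-yl on an aromatic carbon. All three measured steps exchange one aromatic group at this same place: a 1.1-fold lower number from compound 1 to compound 2 (0.06 log units; within the scatter), a 1.1-fold lower number from compound 1 to compound 3 (0.05 log units; within the scatter) and a 1.0-fold higher number from compound 2 to compound 3 (0.01 log units; within the scatter), none beyond the scatter. Another such exchange is therefore expected to give no step beyond the scatter in this assay, so for compound 4 the expected step is no change at the digits printed from compound 3 to compound 4 (within the scatter).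

Compound 4 is estimated at 95 nM, with a range of 45 nM to 200 nM.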

Compound 4, half-maximal effective concentration: 100 nM
Compound 4: middle estimate off by 1.1-fold (0.02 log units), on the low side, within the range that was stated.
By their numbers in this assay, from the lowest: compounds 2, 3, 4 and 1 (each within the scatter of the next).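

In this assay, the 1,2-thiazol-4-yl group, the only sulfur-bearing group shown on this aromatic carbon, stays level with 6-cyanopyridin-2-yl (a 1.1-fold higher number from compound 3 to compound 4 (0.02 log units; within the scatter)), 1H-1,2,3-triazol-1-yl (a 1.1-fold higher number from compound 2 to compound 4 (0.03 log units; within the scatter)) and 1H-pyrazol-1-yl (a 1.1-fold lower number from compound 1 to compound 4 (0.03 log units; within the scatter)). The flat response at this place therefore extends to a five-membered aromatic ring attached through carbon and containing sulfur. No measurement shown accounts for this flat response.

Going by these compounds, whether an amine, a carboxylic acid or a longer chain here would give a step beyond the scatter remains open. Also open, on these data alone, is whether this flat response would persist with a different group elsewhere on the shared core.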